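From cyclopentyl to 3-iodobenzyl on a shared core

This account rests on a few compounds, and the source may have more. Where it says the series, first, only, none or still open, it means among the compounds named here.

In an ADME assay on L6 cells (Rattus norvegicus) for cytotoxicity (on this read-out lower numbers stand for stronger inhibition and higher numbers for weaker inhibition), compound 1 `OC[C@H]1O[C@@H](n2cnc3c(NC4CCCC4)nc(NC4CCCC4)nc32)[C@H](O)[C@@H]1O` gives 97300 nM. Two relatives sit level with it: compound 2 `OC[C@H]1O[C@@H](n2cnc3c(NC4CCCC4)nc(NCCOCc4ccccc4)nc32)[C@H](O)[C@@H]1O` gives 78800 nM, and compound 3 `COc1nc(NC2CCCC2)c2ncn([C@@H]3O[C@H](CO)[C@@H](O)[C@H]3O)c2n1` gives 51600 nM. Compound 1 has no clear place above or below either of them, since its steps to both stay within the scatter.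

Compound 4 `OC[C@H]1O[C@@H](n2cnc3c(NCc4cccc(I)c4)nc(NC4CCCC4)nc32)[C@H](O)[C@@H]1O`, still to be measured, keeps the core of compound 1 and changes one group: 3-iodobenzyl in place of cyclopentyl on a nitrogen on an aromatic ring. Put simply, this is 3-iodobenzyl in place of cyclopentyl on a nitrogen on an aromatic ring.

The closest guide is a 1.2-fold lower number from compound 1 to compound 2 (0.09 log units; within the scatter). That step also puts a new group in place of a cyclopentyl on a nitrogen on an aromatic ring, though not the same cyclopentyl that compound 4 loses. Two further swaps, a 1.9-fold lower number from compound 1 to compound 3 (0.28 log units; within the scatter) and a 1.5-fold lower number from compound 2 to compound 3 (0.18 log units; within the scatter), replace a whole substituent on an aromatic carbon, and neither goes beyond the scatter. Among the measured compounds shown here, none of the measured compounds carries iodine, so that atom remains untested here.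

On this evidence, no change beyond the scatter is expected, and the estimate amounts to a 1.6-fold lower number from compound 1 to compound 4 (0.21 log units; within the scatter). For compound 4 the estimated value is 60000 nM, with an expected range from 25000 nM to 120000 nM.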

Compound 4, half-maximal inhibitory concentration: 51700 nM
Estimate against measurement, compound 4: 1.2-fold (0.06 log units) above; the range from low to high includes it.
By their numbers in this assay, from the lowest: compounds 3, 4, 2 and 1 (each within the scatter of the next).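

This is the first change shown at this cyclopentyl, and in this assay swapping it for 3-iodobenzyl gives a 1.9-fold lower number from compound 1 to compound 4 (0.27 log units; within the scatter), so the step stays within the scatter. The earlier steps shown here replaced the other cyclopentyl or a whole substituent on an aromatic carbon, whereas this one shows that a non-aromatic five-membered ring on this nitrogen can give way to a larger group with a six-membered aromatic ring and an iodine atom, with no clear shift in this read-out. No measurement shown here gives a reason for this result.

A plain benzyl without iodine would show whether the iodine matters at all, and a chain ending in an amine or a carboxylic acid would test a quite different kind of group on the same nitrogen. Since every step printed for this series stays within the scatter, the compounds shown do not reveal which change at this position, if any, would move the number beyond it.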